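The source may hold more compounds than are shown below. What is called first, only, known or untested is meant among the compounds shown, and "the series" means these compounds.

Compound 1 `Cc1cc(Cl)cc(-c2ccnc3cc(CN4C(=O)C5C(C4=O)C5(C)C)sc23)c1C[C@@H]1CNCCO1`: 25 nM
Compound 2 `Cc1cc(Cl)cc(-c2ccnc3cc(CN4C(=O)C5CC5C4=O)sc23)c1C[C@@H]1CNC[C@@H](C)O1`: 60 nM
Compound 3 `Cc1cc(Cl)cc(-c2ccnc3cc(CN4C(=O)C5C(C4=O)C5(C)C)sc23)c1CC1CCCNC1`: 130 nM

In an assay on RKO cells for inhibition of ubiquitin carboxyl-terminal hydrolase 7 (Homo sapiens), read by a luciferase reporter, with a stated time of 18 h (a higher number here means that more compound is needed for the effect, a lower number that less compound is needed), compound 2 stands second highest of the three numbers, above compound 1 and below compound 3, both gaps beyond the scatter. Compound 4 `Cc1cc(Cl)cc(-c2ccnc3cc(CN4C(=O)C5CC5C4=O)sc23)c1C[C@H]1OCCN[C@@H]1C` differs from compound 2 by 3-methylmorpholin-2-yl in place of 6-methylmorpholin-2-yl on a saturated chain carbon bound to an aromatic carbon. Among the compounds with values here, no measured pair isolates a shift of the methyl within this ring. Within the data shown here, the only step touching the amine ring is a 5.2-fold higher number from compound 1 to compound 3 (0.72 log units; beyond the scatter), which exchanges one ring for another and so bears on the present change only loosely; it shows that alterations here move this assay modestly. A small step is therefore expected, with no firm direction. Compound 4 is estimated at 80 nM, between 30 nM and 220 nM, a step of a 1.3-fold higher number from compound 2 to compound 4 (0.12 log units; within the scatter).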

Compound 4, half-maximal effective concentration: 210 nM
Estimate against measurement, compound 4: 2.6-fold (0.42 log units) below; the measured number falls inside the stated range.
By their numbers in this assay, from the lowest: compound 1; then compound 2; then compounds 3 and 4 (each within the scatter of the next).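

In this assay, 3-methylmorpholin-2-yl in place of 6-methylmorpholin-2-yl gives a 3.5-fold higher number from compound 2 to compound 4 (0.54 log units; beyond the scatter), so this position responds to where the methyl sits on the morpholine ring, even with the same atoms and the same counts of donors and acceptors. The earlier step exchanged one ring for another and could not show this. Nothing measured here explains the step. The compounds shown leave open how 3-ethylmorpholin-2-yl or 6-ethylmorpholin-2-yl would compare on the same core, and how the other stereoisomers of 3-methylmorpholin-2-yl would read.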